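A few compounds are considered here, and "the series" means these few. Any claim that something is new, unique, unknown or untested is made for them only; others in the source may bear on it.

Measured in an ADME assay on the whole organism (Rattus norvegicus, strain Sprague-Dawley) for pharmacokinetics, read by LC-MS, with a stated time of 30 min, at a dose of 1 mg/kg by the intravenous route; on this read-out lower numbers stand for slow clearance and higher numbers for fast clearance:
compound 1 `N#Cc1ccc(O[C@H]2CN(S(=O)(=O)c3ccc(Cl)cn3)C[C@@]2(O)CO)cc1F`: 170 mL/min/kg
compound 2 `N#Cc1ccc(O[C@H]2CN(S(=O)(=O)c3ccc(C(F)(F)F)nc3)C[C@@]2(O)CO)cc1F`: 210 mL/min/kg

Within the data shown here, compound 1 stands within the scatter of the only other number. That measured step, a 1.2-fold higher number from compound 1 to compound 2 (0.09 log units; within the scatter), puts 6-(trifluoromethyl)pyridin-3-yl in place of 5-chloropyridin-2-yl on a sulfonyl sulfur. Compound 3 `N#Cc1ccc(O[C@H]2CN(S(=O)(=O)c3ccc(Cl)cn3)C[C@]2(O)CO)cc1F` differs from compound 1 as follows: the two compounds have the same atoms and bonds and differ only in configuration as drawn: 1 of 2 stereo elements differ; a stereocentre at a saturated ring carbon is drawn R in compound 1 and S in compound 3. Among the measured compounds shown here, no measured step changes configuration, so the data give no direct guide, and no step beyond the scatter is expected. The expected step is a 1.1-fold lower number from compound 1 to compound 3 (0.05 log units; within the scatter). For compound 3 the estimate is 150 mL/min/kg, with an expected range of 70 mL/min/kg to 240 mL/min/kg.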

Compound 3, clearance: 150 mL/min/kg
The estimate for compound 3 equals the measured number at the digits printed, within the range that was stated.
By their numbers in this assay, from the lowest: compounds 3, 1 and 2 (each within the scatter of the next).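

In this assay, among these compounds, the only change of configuration gives a 1.1-fold lower number from compound 1 to compound 3 (0.05 log units; within the scatter). At this saturated ring carbon, R and S are therefore not separated on clearance, a point the change on the sulfonyl sulfur could not address. The comparison bears on configuration alone: the fact that compounds 1 and 3 differ only in the configuration as drawn

The compounds shown leave open how the other stereo element, or this same inversion with 6-(trifluoromethyl)pyridin-3-yl on the sulfonyl sulfur, would read. Also open, as far as these compounds go, is whether an amine or a carboxylic acid on the shared core would move clearance beyond the scatter.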